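Stepping from Compound 3 to Compound 4

This account rests on a few compounds, and the source may have more. Where it says the series, first, only, none or still open, it means among the compounds named here.

Compound 1, `Cc1ccc(-c2cc(/N=C3/NC(=O)CS3)cs2)cc1`: > 50000 nM
Compound 2, `COc1ccc(-c2cc(/N=C3/NC(=O)CS3)cs2)cc1`: > 50000 nM
Compound 3, `Cc1ccc(/C=C2\S/C(=N\c3csc(-c4ccc(Cl)cc4)c3)NC2=O)cc1`: 6400 nM

In a functional assay on HT-29 cells (Homo sapiens) for cytotoxicity, read by MTT assay, with a stated time of 72 h (a lower number here means a stronger inhibitor, a higher number a weaker inhibitor), compound 1 reaches only a limit of the assay, > 50000 nM. Compound 2 likewise shows only a limit, > 50000 nM. For the measured compounds named here, the one step between measured compounds, a step that the two limits leave unreadable from compound 1 to compound 2, cannot be read in size for the reason given by the limit of > 50000 nM in this assay, at which 2 of the 3 values shown sit. Going by the values given here, compound 3, with 6400 nM in this assay, is thus the only compound with a number, and it is the starting point for compound 4, `O=C1N/C(=N/c2csc(-c3ccc(Cl)cc3)c2)S/C1=C\c1ccc2ccccc2c1`.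

The change is naphthalen-2-yl in place of 4-methylphenyl on a double-bonded chain carbon bound to a double-bonded ring carbon. Among the compounds with values here, no measured step touches this position, and the single step known, from compound 1 to compound 2, lies elsewhere and is unreadable. The expectation for compound 4 therefore rests on compound 3 alone, and the estimated step of a 1.4-fold lower number from compound 3 to compound 4 (0.15 log units; within the scatter) is small, with wide uncertainty in either direction. Compound 4 is estimated at 4500 nM, with a range from 1000 nM to 25000 nM.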

Compound 4, half-maximal inhibitory concentration: 3700 nM
Estimate against measurement, compound 4: 1.2-fold (0.09 log units) above; the range from low to high includes it.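

For the compounds shown here, this is the first step at this position that can be read, and in this assay it is a 1.7-fold lower number from compound 3 to compound 4 (0.24 log units; within the scatter). Naphthalen-2-yl brings 10 heavy atoms and 2 six-membered aromatic rings of carbon only where 4-methylphenyl has 7 heavy atoms and one such ring, yet this assay does not separate compound 3 from compound 4. On the double-bonded chain carbon bound to a double-bonded ring carbon, this enlargement of the all-carbon aromatic group therefore leaves the reading within the scatter.

The compounds shown leave open whether a group of another kind at this position, such as an amine or a carboxylic acid, would give a step beyond the scatter. The step between the two compounds that reach only a limit also stays unreadable: the limit of > 50000 nM in this assay, at which 2 of the 4 values shown sit.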